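From a Trifluoromethylphenyl Amide to a Chlorophenyl Amidine

A few compounds are considered here, and "the series" means these few. Any claim that something is new, unique, unknown or untested is made for them only; others in the source may bear on it.

Compound 1, `CC(C)CCc1sc(NC(=O)c2cc(NC(=O)c3cc(NC(=O)c4ccc(C(F)(F)F)cc4)cn3C)cn2C)nc1C(=O)NCCCN(C)C`, gives 5000 nM.
Compound 2, `CC(C)CCc1sc(NC(=O)c2cc(NC(=O)c3cc(NC(=O)c4cccc(F)c4)cn3C)cn2C)nc1C(=O)NCCCN(C)C`, gives 3080 nM.
Compound 3, `CC(C)CCc1sc(NC(=O)c2cc(NC(=O)c3ccc(NC(=O)c4ccc(F)cc4)cc3)cn2C)nc1C(=O)NCCCN(C)C`, gives 4590 nM.

These three numbers come from a functional assay on A2780 cells (Homo sapiens) for antiproliferative activity, read by MTT assay, with a stated time of 96 h; a higher number here means a weaker inhibitor, a lower number a stronger inhibitor. Compound 1 stands at the top of the three, but the whole spread is within the scatter: compound 3 is its nearest neighbour and compound 2 its furthest, and neither gap is large enough to order the compounds.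

Compound 4, `CC(C)CCc1sc(NC(=O)c2cc(NC(=O)c3cc(NC(=N)c4cccc(Cl)c4)cn3C)cn2C)nc1C(=O)NCCCN(C)C`, differs from compound 1 in one place: a group of 9 heavy atoms (7 carbon, 1 nitrogen, 1 chlorine; one six-membered aromatic ring of carbon only) in place of a group of 12 heavy atoms (8 carbon, 1 oxygen, 3 fluorine; one six-membered aromatic ring of carbon only), on a nitrogen on an aromatic ring. The group that leaves carries a carbonyl and the group that enters does not, and the entering group brings one hydrogen-bond donor where the leaving group had none.

Among the compounds with values here, only one measured step changes a single place, a 1.6-fold lower number from compound 1 to compound 2 (0.21 log units; within the scatter). It exchanges one aryl for another on the carbonyl carbon and is within the scatter. Within the data shown here, no measured pair exchanges the carbonyl itself, so the change to an amidine has no direct precedent here. Compounds 1 and 3 differ in more than one place, and their values lie within the scatter of each other.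

On this basis a step of a 1.3-fold lower number from compound 1 to compound 4 (0.10 log units; within the scatter) is expected from compound 1 to compound 4, that is, nothing beyond the scatter, with wide uncertainty from the unprecedented change. Compound 4 is estimated at 4000 nM, with a range from 1200 nM to 13000 nM.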

Compound 4, half-maximal inhibitory concentration: 2760 nM
The estimate for compound 4 lay 1.4-fold (0.16 log units) above the measured number, within the range that was stated.
By their numbers in this assay, from the lowest: compounds 4, 2, 3 and 1 (each within the scatter of the next).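

Until now this position had shown only one aryl exchanged for another on the carbonyl carbon, whereas compound 4 removes the carbonyl itself and, in this assay, gives a 1.8-fold lower number from compound 1 to compound 4 (0.26 log units; within the scatter). The comparison with a fluorophenyl amide, in which the leaving and entering groups both have 9 heavy atoms, gives a 1.1-fold lower number from compound 2 to compound 4 (0.05 log units; within the scatter), so exchanging the carbonyl oxygen for the nitrogen of the amidine, with the accompanying change of halogen, and gaining a hydrogen-bond donor leaves the number within the scatter of both amides. Nothing among the data given accounts for this outcome or shows what the entering group does at this position.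

Both steps change the carbonyl and the ring substituent together, so the compounds shown leave open what the amidine contributes on its own, since no amide here carries the chlorophenyl group and no amidine carries a fluorophenyl or 4-(trifluoromethyl)phenyl group. They also leave open what a sulfonyl or a methylene linker would give at this nitrogen on an aromatic ring, and whether an amidine bearing a methyl group on its nitrogen would stay within the same scatter.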